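A few compounds are considered here, and "the series" means these few. Any claim that something is new, unique, unknown or untested is made for them only; others in the source may bear on it.

Compound 3 `O=C(CN1CN(c2ccccc2)C2(CCN(C(=O)c3ccc(C4CCCCC4)cc3)CC2)C1=O)NCO` is one of three related amides tested in an assay on HEK293 cells for displacement of a labelled ligand from NPC1-like intracellular cholesterol transporter 1 (Homo sapiens) (on this read-out lower numbers stand for stronger inhibition and higher numbers for weaker inhibition), where compound 3 gives 8300 nM. Compound 1 `CC(C)(C)OC(=O)NC1CCCN(C(=O)CN2CN(c3ccccc3)C3(CCN(C(=O)c4ccc(C5CCCCC5)cc4)CC3)C2=O)C1` gives 4400 nM and compound 2 `CS(=O)(=O)NCCCNC(=O)CN1CN(c2ccccc2)C2(CCN(C(=O)c3ccc(C4CCCCC4)cc3)CC2)C1=O` gives 3800 nM; compound 3 thus shows the highest of the three numbers, nearest to compound 1 and furthest from compound 2. For the measured compounds named here, the only single-site step among them, a 2.2-fold higher number from compound 2 to compound 3 (0.34 log units; beyond the scatter), is modest. Compound 4 `CCOC(=O)C1CCCN(C(=O)CN2CN(c3ccccc3)C3(CCN(C(=O)c4ccc(C5CCCCC5)cc4)CC3)C2=O)C1` differs from compound 3 by 3-(ethoxycarbonyl)piperidin-1-yl in place of (hydroxymethyl)amino on a carbonyl carbon. Going by the values given here, no measured step covers this exchange directly; the replacement of the small amide substituent by a larger ring-bearing group is expected to lower the number somewhat, about a 2.1-fold lower number from compound 3 to compound 4 (0.32 log units; beyond the scatter), toward the value of compound 1. Compound 4 is therefore estimated at 4000 nM, within 1500 nM to 11000 nM.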

Compound 4, half-maximal inhibitory concentration: 4200 nM
Beside the measured number, compound 4's estimate is 1.1-fold (0.02 log units) below it, within the range that was stated.
By their numbers in this assay, from the lowest: compounds 2, 4, 1 and 3 (each within the scatter of the next, the first and the last beyond it).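

On the carbonyl carbon, the much larger 3-(ethoxycarbonyl)piperidin-1-yl group, which carries no hydrogen-bond donors, replaces (hydroxymethyl)amino with a 2.0-fold lower number from compound 3 to compound 4 (0.30 log units; within the scatter) and so leaves the two compounds unseparated. Exchanging (3-(methanesulfonamido)propyl)amino for that group gives a 1.1-fold higher number from compound 2 to compound 4 (0.04 log units; within the scatter) and ethoxycarbonyl in place of (tert-butoxycarbonyl)amino on the saturated ring carbon gives a 1.0-fold lower number from compound 1 to compound 4 (0.02 log units; within the scatter) so this position shows no clear preference among these groups. No measurement bears on why these numbers stay so close.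

Going by these compounds, whether a carboxylic acid or a primary amine in place of the ethoxycarbonyl would move the number beyond the scatter remains open.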